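The compounds below may be only part of what the source reports. "The series", "measured", "known", "first", "only" and "open" are said of these compounds alone.

Measured so far:
compound 1 `Nc1scc(CN2CCN(c3ccc(OC(F)(F)F)cc3)CC2)c1C(=O)c1ccc(Cl)cc1` — 1%
compound 2 `Nc1scc(CN2CCN(c3cccnc3)CC2)c1C(=O)c1ccc(Cl)cc1` — 0%

In an assay on CHO cells for displacement of a labelled ligand from adenosine receptor A3 (Homo sapiens), read by scintillation counting, with a stated time of 120 min, tested at 10 uM (on this read-out lower numbers stand for less inhibition and higher numbers for more inhibition at the one concentration tested (going by the name of the read-out)), compound 1 gives 1% and compound 2 gives 0%. Compound 2 sits together with compound 1 at the foot of the measured range; the step of a number 1 percentage points lower from compound 1 to compound 2 (within the scatter) lies within the scatter, so the two are not separated by the assay.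

Compound 3 `Nc1scc(CN2CCN(c3ccncc3)CC2)c1C(=O)c1ccc(Cl)cc1` has not been measured. It differs from compound 2 only at the amine nitrogen in the ring: pyridin-4-yl in place of pyridin-3-yl on an amine nitrogen in a ring. Among the compounds with values here, the one measured step that touches this position, from compound 1 to compound 2, swapped a much larger group for pyridin-3-yl and moved the read-out by a number 1 percentage points lower from compound 1 to compound 2 (within the scatter), within the scatter. A smaller rearrangement at the same position is therefore expected to give no step beyond the scatter, so the expected step is a number 2 percentage points higher from compound 2 to compound 3 (within the scatter).

Compound 3 is estimated at 2%, with a range from -8% to 12%.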

Compound 3, a percentage reported as inhibition, at one concentration (the size of the read-out at that concentration, not a potency): 2%
For compound 3 middle estimate and measured number coincide at the digits printed; measured number inside the range.
By their numbers in this assay, from the lowest: compounds 2, 1 and 3 (each within the scatter of the next).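

In this assay, pyridin-4-yl in place of pyridin-3-yl on an amine nitrogen in a ring gives a number 2 percentage points higher from compound 2 to compound 3 (within the scatter), so the place of the nitrogen within the pyridine ring does not separate these two compounds. The larger exchange, pyridin-4-yl in place of 4-(trifluoromethoxy)phenyl, gives a number 1 percentage points higher from compound 1 to compound 3 (within the scatter), so the flat result from the earlier pair now holds across three aromatic groups at this position. Nothing on hand accounts for this flat result.

From the compounds shown here alone, whether any group on this ring nitrogen can lift the read-out remains open, since a non-aromatic group such as a simple alkyl chain or one carrying a carboxylic acid lies outside these three compounds. Also open, going by these compounds, is whether a change elsewhere on the shared core, such as a cyclohexyl group in place of the 4-chlorophenyl on the carbonyl, would move the read-out.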